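Chloro to methoxy exchange tested on a second core

The compounds below may be only part of what the source reports. "The series", "measured", "known", "first", "only" and "open" are said of these compounds alone.

Compound 1 `COc1cc2c(/C=C3/C(=O)Nc4ccc(Cl)cc43)c(Cl)n(Cc3cc(OC)c(OC)c(OC)c3)c2cc1C` and compound 2 `COc1ccc2c(c1)/C(=C\c1c(Cl)n(Cc3cc(OC)c(OC)c(OC)c3)c3cc(C)c(OC)cc13)C(=O)N2` are built on one core; compound 3 `COc1c(/C=C2/C(=O)Nc3ccc(Cl)cc32)c2ccccc2n1-c1ccccc1` and the unmeasured compound 4 `COc1ccc2c(c1)/C(=C\c1c(OC)n(-c3ccccc3)c3ccccc13)C(=O)N2` are built on another. The difference between the two cores is not broken down here.

In a functional assay on cells (Cancer cell lines, Homo sapiens) for cytotoxicity, with a stated time of 48 h (a lower number here means a stronger inhibitor of growth, a higher number a weaker inhibitor of growth), compound 1 gives 3720 nM. Compound 2 in this assay gives 33100 nM, and the exchange methoxy in place of chloro on an aromatic carbon produces an 8.9-fold higher number from compound 1 to compound 2 (0.95 log units; beyond the scatter). Compound 3 in this assay gives 8510 nM, which is the second highest of the three measured numbers: higher than the number for compound 1 and lower than that for compound 2, both gaps beyond the usual scatter.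

Compound 4 is derived from compound 3 by methoxy in place of chloro on an aromatic carbon. Among the compounds with values here, the two descriptions of the place of the change agree word for word, so this is the same change as that from compound 1 to compound 2, now made on the core of compound 3, and no other pair in the set shows it.

For compound 4 the expected step is a 6.5-fold higher number from compound 3 to compound 4 (0.81 log units; beyond the scatter), a rise of broadly the same kind and size because the same change gave an 8.9-fold higher number from compound 1 to compound 2 (0.95 log units; beyond the scatter); this expectation rests on a single precedent on a different core, so the range is kept wide. Compound 4 is therefore estimated at 55000 nM in this assay, with the expected range from 15000 nM to 200000 nM.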

Compound 4, concentration for 50% growth inhibition: 2000 nM
Compound 4: middle estimate off by 28-fold (1.44 log units), on the high side; measured number outside the range, below it.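

Methoxy in place of chloro on an aromatic carbon gives a 4.3-fold lower number from compound 3 to compound 4 (0.63 log units; beyond the scatter) in this assay and so runs in the opposite direction to the step on the core of compound 1, where the same exchange weakens growth inhibition. The direction of this exchange therefore does not carry from one core to the other in this series, and a step read on one core gives no safe forecast for the other, as the two steps set side by side show: the same change on two cores in this assay, an 8.9-fold higher number (0.95 log units; beyond the scatter) from compound 1 to compound 2 and a 4.3-fold lower number (0.63 log units; beyond the scatter) from compound 3 to compound 4, 38-fold (1.58 log units) apart, beyond the scatter of two such steps. This does not show which of the structural differences between the two cores goes with the reversal, nor why it occurs, and each core offers a single pair, so neither step has been repeated and no general rule for either core can be drawn.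

The compounds shown hold only chloro and methoxy at the exchanged place, so it remains open how other groups there, such as fluoro, ethoxy or an amine, would behave on either core. Within the data shown here, it also remains open whether the exchange on a further core would follow the step seen with compound 2 or the one seen with compound 4.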